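A few compounds are considered here, and "the series" means these few. Any claim that something is new, unique, unknown or untested is made for them only; others in the source may bear on it.

Compound 2 `COc1ccc(-c2cnc(NC(=O)CCc3ccccc3)n2C)cc1` is the starting point of this account. In a toxicity assay on THP-1 cells (Homo sapiens) for inhibition (on this read-out higher numbers stand for lower toxicity in this test and lower numbers for higher toxicity in this test), compound 2 returns only a limit of the assay, > 100000 nM, and this is the limit of > 100000 nM in this assay, at which 1 of the 3 values shown sits. Two further compounds share the core of compound 2. Compound 1 `Cn1c(-c2ccc(C#N)cc2)cnc1NC(=O)c1ccc(F)cc1` also returns a limit in this assay, > 50000 nM. Compound 3 `Cn1c(-c2ccccc2Cl)cnc1NC(=O)c1ccc(F)cc1` returns a limit as well, > 50000 nM. These two values stand at the limit of > 50000 nM in this assay, at which 2 of the 3 values shown sit. Going by the values given here, the only step between measured compounds, a step that the two limits leave unreadable from compound 1 to compound 3, puts 2-chlorophenyl in place of 4-cyanophenyl on an aromatic carbon, and its size is not readable from two limits.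

Compound 4 `COc1ccc(-c2cnc(NC(=O)c3ccccc3C)n2C)cc1` is not yet measured. It differs from compound 2 by 2-methylphenyl in place of phenethyl on a carbonyl carbon. Among the compounds with values here, no measured step touches the group on the carbonyl carbon, and all three known values are limits at the high end, so the data offer no direction for this change. Compound 4 is expected to move by an at least 1.2-fold lower number from compound 2 to compound 4 (0.09 log units; that floor lies within the scatter), which is nothing beyond the scatter. The estimate for compound 4 in this assay is 80000 nM, within a range from 30000 nM to 200000 nM.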

Compound 4, half-maximal cytotoxic concentration: > 100000 nM
Compound 4: no number, only a limit; the forecaster's own chance of this, stated with the estimate: 70%; middle value at least 1.2-fold (0.09 log units) away from the limit.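

Compound 2 and compound 4 both return only limits in this assay, and the step between them cannot be read. The compounds shown leave open what actual number any of them would give in this assay, and whether changing the group on the carbonyl carbon shifts it.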